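From 3-Chlorophenyl to 2-Fluorophenyl on the Amide Nitrogen

A few compounds are considered here, and "the series" means these few. Any claim that something is new, unique, unknown or untested is made for them only; others in the source may bear on it.

Of the compounds shown here, three sharing one core have been tested in a functional assay on DU-145 cells (Homo sapiens) for inhibition, read by MTT assay, with a stated time of 24 h; a lower number here means a stronger inhibitor, a higher number a weaker inhibitor. Compound 1, with the structure `CCOC(=O)C1=Cc2ccccc2OC1(OCc1cn(CC(=O)Nc2cccc(Cl)c2)nn1)C(F)(F)F`, gives 10100 nM in this assay. Compound 2, with the structure `CCOC(=O)C1=Cc2ccccc2OC1(OCc1cc(-c2ccc(Br)cc2)no1)C(F)(F)F`, gives 71700 nM in this assay. Compound 3, with the structure `O=C(O)C1=Cc2ccccc2OC1(OCc1cc(-c2ccc(F)cc2F)no1)C(F)(F)F`, reaches only the limit of this assay, > 150000 nM, so no number is known for it; this is the reading described as the limit of > 150000 nM in this assay, at which 1 of the 3 values shown sits. Among the two actual numbers, compound 1 holds the lower one, and its gap to compound 2 lies beyond the usual scatter of repeated measurements, so compound 1 is the stronger inhibitor of the two.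

Compound 4, with the structure `CCOC(=O)C1=Cc2ccccc2OC1(OCc1cn(CC(=O)Nc2ccccc2F)nn1)C(F)(F)F`, has not yet been measured. It differs from compound 1 in one place: 2-fluorophenyl in place of 3-chlorophenyl on an amide-type nitrogen. Among the compounds with values here, no measured pair in this set differs by a change of this kind, so its size has to be judged without a direct precedent. A halogen swap on the aryl group of an amide is usually a small adjustment, and the expected step from compound 1 to compound 4 is a 1.5-fold higher number from compound 1 to compound 4 (0.17 log units; within the scatter), roughly within or just beyond the scatter. Compound 4 is therefore estimated at 15000 nM, with a plausible range from 5000 nM to 45000 nM.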

Compound 4, half-maximal inhibitory concentration: 33900 nM
Beside the measured number, compound 4's estimate is 2.3-fold (0.35 log units) below it, and the stated range covers the measured number.
By their numbers in this assay, from the lowest: compound 1; then compound 4; then compound 2. At a limit, above all of these: compound 3.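

The aryl group on the amide-type nitrogen is not a silent position: in this assay, putting 2-fluorophenyl in place of 3-chlorophenyl gives a 3.4-fold higher number from compound 1 to compound 4 (0.53 log units; beyond the scatter), a modest step but one that exceeds ordinary measurement noise. Within the data shown here, this is the first pair in the set that differs in one place only, so the shift in potency can be tied to this single swap rather than to several differences at once. The two groups match in heavy-atom count, ring type, hydrogen-bond donors and acceptors and net charge, so those counts do not separate them, and nothing measured here accounts for the weaker inhibition of the 2-fluorophenyl compound.

The halogen and its place on the ring change together in this one step, so the compounds shown cannot tell whether the swap from chlorine to fluorine or the change of ring position matters more. A plain phenyl ring with no halogen, or the same ring carrying a methoxy group or an amine, would show whether this position needs a halogen at all.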